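The compounds below may be only part of what the source reports. "The series", "measured", "known", "first", "only" and "open" are said of these compounds alone.

Series notes, triazole aryl variation. Compound 2 `CC1(C)[C@H]2CC[C@]1(C)N(Cc1cn(-c3ccccc3Br)nn1)C(=O)C2` gives 60 nM in a functional assay on LoVo cells (Homo sapiens) for inhibition, read by MTT assay, with a stated time of 24 h; a higher number here means a weaker inhibitor, a lower number a stronger inhibitor. Compound 1 `COc1ccccc1-n1cc(CN2C(=O)C[C@@H]3CC[C@@]2(C)C3(C)C)nn1` gives 70 nM, and compound 3 `CC1(C)[C@H]2CC[C@]1(C)N(Cc1cn(-c3ccc(C#N)cc3)nn1)C(=O)C2` gives 90 nM; the steps of a 1.2-fold lower number from compound 1 to compound 2 (0.07 log units; within the scatter), a 1.3-fold higher number from compound 1 to compound 3 (0.11 log units; within the scatter) and a 1.5-fold higher number from compound 2 to compound 3 (0.18 log units; within the scatter) all stay within the scatter, so compound 2 sits with the others rather than apart. Compound 4 `Cc1cccc(-n2cc(CN3C(=O)C[C@@H]4CC[C@@]3(C)C4(C)C)nn2)c1` is not yet measured. Change from compound 2: 3-methylphenyl in place of 2-bromophenyl on an aromatic nitrogen. The steps bearing on it, a 1.5-fold higher number from compound 2 to compound 3 (0.18 log units; within the scatter) and a 1.3-fold higher number from compound 1 to compound 3 (0.11 log units; within the scatter), are also aryl exchanges on that nitrogen and were both within the scatter, so no step beyond the scatter is expected for a 1.1-fold higher number from compound 2 to compound 4 (0.03 log units; within the scatter). The estimate for compound 4 is therefore 65 nM, with a range of 30 nM to 140 nM.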

Compound 4, half-maximal inhibitory concentration: 50 nM
The estimate for compound 4 lay 1.3-fold (0.11 log units) above the measured number; low and high end bracket the measured number.
By their numbers in this assay, from the lowest: compounds 4, 2, 1 and 3 (each within the scatter of the next).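

In this assay the 3-methylphenyl group brings a substituent of carbon only onto the aromatic nitrogen, and the steps of a 1.2-fold lower number from compound 2 to compound 4 (0.08 log units; within the scatter) and a 1.4-fold lower number from compound 1 to compound 4 (0.15 log units; within the scatter) and a 1.8-fold lower number from compound 3 to compound 4 (0.26 log units; within the scatter) all stay within the scatter. The 2-bromophenyl, 2-methoxyphenyl, 4-cyanophenyl and 3-methylphenyl groups are therefore not told apart at this position by this read-out. Nothing on hand explains this flat response. 

Still open, going by these compounds, is whether a phenyl ring carrying an amine or a carboxylic acid would stay in the same range. Also open, on these data alone, is whether a saturated alkyl chain in place of the aryl ring would do so.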